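Acetylation of a Hydroxyl Group in a Cytotoxic Diterpenoid Series

The compounds below may be only part of what the source reports. "The series", "measured", "known", "first", "only" and "open" are said of these compounds alone.

Compound 1 `C=C1CC[C@@H]2[C@](C)(CO)[C@H](OC(C)=O)CC[C@@]2(C)[C@@H]1C/C=C1/C(=O)OC[C@H]1O` was tested in a functional assay on Col2 cells (Homo sapiens) for cytotoxicity, read by sulforhodamine B assay (a higher number here means that more compound is needed for the effect, a lower number that less compound is needed), where compound 1 gives 27.2 uM. Compound 2 `C=C1CC[C@@H]2[C@](C)(CO)[C@H](OC(C)=O)CC[C@@]2(C)[C@@H]1C/C=C1/C(=O)OC[C@H]1OC(C)=O` differs from compound 1 by acetyl in place of hydrogen on an oxygen on a saturated carbon; in this assay compound 2 gives 10.2 uM. That single change produced a 2.7-fold lower number from compound 1 to compound 2 (0.43 log units; beyond the scatter), so the acetylated compound needed less compound for the half-maximal effect.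

Compound 3 `C=C1CC[C@@H]2[C@](C)(COC(C)=O)[C@H](O)CC[C@@]2(C)[C@@H]1C/C=C1/C(=O)OC[C@H]1O` is built from the same atoms as compound 1 but joined differently; the difference between the two cores is not broken down here. In this assay compound 3 gives 12.9 uM, a number within the scatter of that of compound 2 and beyond the scatter from that of compound 1.

Compound 4 `C=C1CC[C@@H]2[C@](C)(COC(C)=O)[C@H](O)CC[C@@]2(C)[C@@H]1C/C=C1/C(=O)OC[C@H]1OC(C)=O` has not yet been measured. Going by the values given here, it differs from compound 3 by acetyl in place of hydrogen on an oxygen on a saturated carbon, the same change as the one from compound 1 to compound 2, made at a place described in the same words. Among the compounds with values here, since the only measured example of this change, between compound 1 and compound 2, gave a 2.7-fold lower number from compound 1 to compound 2 (0.43 log units; beyond the scatter), a step of similar size is expected here, though one example is a thin basis. The expected step from compound 3 to compound 4 is a 2.3-fold lower number from compound 3 to compound 4 (0.37 log units; beyond the scatter). Compound 4 is therefore estimated to give about 5.5 uM in this assay, with a plausible range from 2.5 uM to 12 uM.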

Compound 4, concentration for half-maximal effect: 15.2 uM
Compound 4: middle estimate off by 2.8-fold (0.44 log units), on the low side; the measured number lies above the stated range.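

In this assay, putting acetyl in place of hydrogen on compound 3 gave a 1.2-fold higher number from compound 3 to compound 4 (0.07 log units; within the scatter), so compound 4 cannot be told apart from compound 3 in this measurement. The same replacement therefore did not behave alike on the two cores, and the difference between the two outcomes is larger than measurement scatter alone would explain: the same change on two cores in this assay, a 2.7-fold lower number (0.43 log units; beyond the scatter) from compound 1 to compound 2 and a 1.2-fold higher number (0.07 log units; within the scatter) from compound 3 to compound 4, 3.1-fold (0.50 log units) apart, beyond the scatter of two such steps

Going by these compounds alone, this shows that the step seen on the core of compound 1 cannot simply be carried over to the core of compound 3, even when the change is described in the same words, but it does not show which structural difference between the cores is responsible, and with only two pairs it gives no general rule for the series.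

The compounds shown leave open how this hydroxy oxygen would respond to anything other than acetyl, such as a longer chain in the form of a butanoyl ester, or to replacement of the hydroxy by an amine. Within the data shown here, they also leave open whether either of the two outcomes would recur on a third core, which would help indicate whether the result for compound 2 or the one for compound 4 is more typical of the change.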